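The source may hold more compounds than are shown below. What is called first, only, known or untested is meant among the compounds shown, and "the series" means these compounds.

Among the compounds with values here, in a functional assay on SK-HEP1 cells (Homo sapiens) for inhibition, read by MTT assay, with a stated time of 72 h (a lower number here means a stronger inhibitor, a higher number a weaker inhibitor), compound 3 `Nc1nc2cc(-c3nn(CCCCCC(=O)NO)c4ncnc(N)c34)ccc2o1` gives 3080 nM, the lowest number of the three measured so far, against compound 1 `Nc1ncnc2c1c(-c1cnc3[nH]ccc3c1)nn2CCCCCCCCC(=O)NO` at 11200 nM and compound 2 `Nc1ncnc2c1c(-c1cnc3[nH]ccc3c1)nn2CCCCCCCCCC(=O)NO` at 23500 nM. Compound 4 `Nc1nc2cc(-c3nn(CCCCCCC(=O)NO)c4ncnc(N)c34)ccc2o1` differs from compound 3 by one change: (hydroxycarbamoyl)methyl in place of hydroxycarbamoyl on a saturated chain carbon, five bonds along the chain from an aromatic nitrogen. Within the data shown here, only one measured step bears on it: a 2.1-fold higher number from compound 1 to compound 2 (0.32 log units; beyond the scatter). That step is the same replacement, but eight bonds along the chain from an aromatic nitrogen and in compounds that differ elsewhere from compound 3. This single modest step is thin support, so only a small rise in this assay is expected, and it may stay within the scatter. The expected step is a 1.5-fold higher number from compound 3 to compound 4 (0.16 log units; within the scatter). For compound 4 the estimated value is 4500 nM, with an expected range of 1700 nM to 12000 nM.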

Compound 4, half-maximal inhibitory concentration: 2690 nM
The estimate for compound 4 lay 1.7-fold (0.22 log units) above the measured number; the measured number falls inside the stated range.
By their numbers in this assay, from the lowest: compounds 4 and 3 (each within the scatter of the next); then compound 1; then compound 2.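

On the core of compound 3, (hydroxycarbamoyl)methyl in place of hydroxycarbamoyl, five bonds along the chain from an aromatic nitrogen, gives a 1.1-fold lower number from compound 3 to compound 4 (0.06 log units; within the scatter) in this assay. The rise seen on the core of compound 1 therefore does not recur at this place, and this change has no readable effect here. The two steps still cannot be told apart: the same change on two cores in this assay, a 2.1-fold higher number (0.32 log units; beyond the scatter) from compound 1 to compound 2 and a 1.1-fold lower number (0.06 log units; within the scatter) from compound 3 to compound 4, 2.4-fold (0.38 log units) apart, within the scatter of two such steps

From the compounds shown here alone, a longer chain on the core of compound 4 remains open, as does a carboxylic acid in place of the hydroxycarbamoyl end. The compounds shown also leave the effect of the core unseparated from that of chain length, as no two cores carry the same chain.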